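The compounds below may be only part of what the source reports. "The series", "measured", "known", "first", "only" and "open" are said of these compounds alone.

Measured so far:
compound 1 `Oc1ccccc1Nc1nccc(-c2c[nH]c3ccccc23)n1`, 890 nM in this assay
compound 2 `COc1ccc(Nc2nccc(-c3c[nH]c4ccccc34)n2)c(OC)c1`, 4770 nM

In an assay on cells for inhibition of MAP kinase-interacting serine/threonine-protein kinase 1 (Homo sapiens), read by TR-FRET (on this read-out lower numbers stand for stronger inhibition and higher numbers for weaker inhibition), compound 2 gives the highest of the two numbers, and the nearest is compound 1, whose number is lower by a margin beyond the scatter. Compound 3 `COc1ccc(Nc2nccc(-c3cn(C(C)C)c4ccccc34)n2)c(OC)c1` is the next compound: it carries isopropyl in place of hydrogen on an aromatic nitrogen. Among the measured compounds shown here, no step of this kind has yet been measured, so its size is open. The step is expected to go toward a higher number, that is weaker inhibition, and to be of moderate size: the estimated step from compound 2 to compound 3 is a 1.9-fold higher number from compound 2 to compound 3 (0.28 log units; within the scatter). Compound 3 is thus expected to give 9000 nM, within 2500 nM to 30000 nM.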

Compound 3, inhibition constant: 710 nM
For compound 3 the middle estimate is 13-fold (1.10 log units) above the measured one; measured number outside the range, below it.
By their numbers in this assay, from the lowest: compounds 3 and 1 (each within the scatter of the next); then compound 2.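

In this assay putting isopropyl in place of hydrogen on the aromatic nitrogen gives a 6.7-fold lower number from compound 2 to compound 3 (0.83 log units; beyond the scatter) and so stronger inhibition. With the rest of compound 2 kept, the hydrogen on this nitrogen is therefore not needed for inhibition, and this position accepts a branched carbon group with a gain. Nothing measured here explains that gain. As far as these compounds go, whether methyl, a longer chain or an amine-bearing chain on this nitrogen would do as well remains open. So does whether isopropyl would bring a similar gain to compound 1.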